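A few compounds are considered here, and "the series" means these few. Any claim that something is new, unique, unknown or untested is made for them only; others in the source may bear on it.

Of the compounds shown here, two built on one shared core have been measured so far. Compound 1 `CCc1cc(/C=C/C(=O)c2ccccc2NC(=O)NS(=O)(=O)c2ccc(C)cc2)cc(OC)c1OC` and compound 2 `Cc1ccc(S(=O)(=O)NC(=O)Nc2ccccc2C(=O)/C=C/c2ccccc2O)cc1` were tested in an ADME assay on the whole organism for cytotoxicity, with Artemia salina as the target, with a stated time of 24 h; on this read-out lower numbers stand for an effect already at smaller amounts and higher numbers for an effect only at larger amounts of compound: compound 1 gives 19.2 ug/mL and compound 2 gives 32.3 ug/mL. The step of a 1.7-fold higher number from compound 1 to compound 2 (0.23 log units; within the scatter) is the only one available. Compound 2 thus stands at the highest of the two numbers, with compound 1 within the scatter of it. Compound 3 `Cc1ccc(S(=O)(=O)NC(=O)Nc2ccccc2C(=O)/C=C/c2cc(O)ccc2[N+](=O)[O-])cc1` differs from compound 2 by 5-hydroxy-2-nitrophenyl in place of 2-hydroxyphenyl on a double-bonded chain carbon bound to a double-bonded chain carbon. Among the measured compounds shown here, only the step from compound 1 to compound 2 bears on this change, since it also swaps the group at this place, and it stayed within the scatter. For compound 3 the expected step of a 1.1-fold lower number from compound 2 to compound 3 (0.03 log units; within the scatter) is therefore no larger than the scatter. In this assay compound 3 is expected to give about 30 ug/mL, within a range from 15 ug/mL to 60 ug/mL.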

Compound 3, concentration for half-maximal effect: 18.3 ug/mL
Beside the measured number, compound 3's estimate is 1.6-fold (0.21 log units) above it, and the stated range covers the measured number.
By their numbers in this assay, from the lowest: compounds 3, 1 and 2 (each within the scatter of the next).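

In this assay, 5-hydroxy-2-nitrophenyl in place of 2-hydroxyphenyl gives a 1.8-fold lower number from compound 2 to compound 3 (0.25 log units; within the scatter), and the same group in place of 3-ethyl-4,5-dimethoxyphenyl gives a 1.0-fold lower number from compound 1 to compound 3 (0.02 log units; within the scatter). All three substituted phenyl groups at this place now lie within the scatter of one another, and this includes a group with a nitro substituent and more hydrogen-bond acceptors. From the compounds shown here alone, whether a carboxylic acid, an amine or a longer chain at this place would move the number beyond the scatter remains open. Nothing available explains these numbers.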